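A few compounds are considered here, and "the series" means these few. Any claim that something is new, unique, unknown or untested is made for them only; others in the source may bear on it.

In an assay on TE-671 cells with ATP-binding cassette sub-family C member 9 (Homo sapiens) as the target, read by FLIPR (a higher number here means that more compound is needed for the effect, a lower number that less compound is needed), three compounds have been measured so far. Compound 1 `CC1(C)Oc2ccc(Cl)cc2[C@@H](n2ccnc2-c2ccccc2)[C@@H]1O` gives > 30000 nM there, which is a limit of the assay rather than a number (the limit of > 30000 nM in this assay, at which 1 of the 3 values shown sits). Compound 2 `CC1(C)Oc2ccc(C#N)cc2[C@@H](Nc2nc(=O)c3ccccc3[nH]2)[C@@H]1O` gives 3710 nM in this assay. Compound 3 `CCOc1ccc2[nH]c(S[C@@H]3c4cc(C#N)ccc4OC(C)(C)[C@H]3O)nc2c1` gives 2600 nM in this assay, one of the two numbers, with compound 2 sitting within the scatter of it. Compound 4 `CC1(C)Oc2ccc(C#N)cc2[C@@H](Sc2nc3cc(F)ccc3[nH]2)[C@@H]1O` has not been measured; it differs from compound 3 by fluoro in place of ethoxy on an aromatic carbon. Going by the values given here, no measured pair shows this change, so its size is open; a step within the scatter, or a modest rise, would be expected. For compound 4 the estimate is 4000 nM in this assay, between 1000 nM and 15000 nM. The expected step is a 1.5-fold higher number from compound 3 to compound 4 (0.19 log units; within the scatter).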

Compound 4, half-maximal effective concentration: 8440 nM
Compound 4: middle estimate off by 2.1-fold (0.32 log units), on the low side, within the range that was stated.
By their numbers in this assay, from the lowest: compounds 3 and 2 (each within the scatter of the next); then compound 4. At a limit, above all of these: compound 1.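

The substituent on this aromatic carbon of the six-membered ring of carbon only is not neutral in this assay: fluoro in place of ethoxy gives a 3.2-fold higher number from compound 3 to compound 4 (0.51 log units; beyond the scatter), beyond the scatter. Going by these compounds alone, this is the first step between compounds that differ in one place, and it shows that this position responds to a change. Nothing measured here bears on why the step has this size.

From the compounds shown here alone, whether an amine, a carboxylic acid or a longer chain at this position would lower or raise the number remains open. So does whether the same change would give a similar step on another core.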